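From Fluoro to Tert-Butyl on an Aromatic Carbon

A few compounds are considered here, and "the series" means these few. Any claim that something is new, unique, unknown or untested is made for them only; others in the source may bear on it.

- compound 1 `CCc1ccc(SCc2ccc(/C=C/C(=O)Nc3ccccc3N)cc2)cc1` gives 68.6%
- compound 2 `Nc1ccccc1NC(=O)/C=C/c1ccc(CSc2ccc(F)cc2)cc1` gives 59.1%

In a functional assay on A549 cells (Homo sapiens) for inhibition, read by CCK-8 assay, with a stated time of 72 h, tested at 8 uM (on this read-out lower numbers stand for less inhibition of growth and higher numbers for more inhibition of growth at the one concentration tested), compound 2 gives 59.1%, which lies within the scatter of compound 1 at 68.6%. The next compound, compound 3 `CC(C)(C)c1ccc(SCc2ccc(/C=C/C(=O)Nc3ccccc3N)cc2)cc1`, has not yet been measured. It carries tert-butyl in place of fluoro on an aromatic carbon, para to a large group (tert-butyl in place of fluoro on an aromatic carbon). For the measured compounds named here, only one measured step bears on this change: a number 9.5 percentage points lower from compound 1 to compound 2 (within the scatter), with fluoro in place of ethyl on an aromatic carbon. Going by the values given here, that step stays within the scatter, and no measured compound yet carries tert-butyl. Read in reverse, it gives only a weak hint of a higher number in this assay, so no step beyond the scatter is expected. The expected change is a number 5.9 percentage points higher from compound 2 to compound 3 (within the scatter). For compound 3 the estimate is 65%, with an expected range of 52% to 78%.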

Compound 3, percent growth inhibition at one concentration: 79.8%
The estimate for compound 3 lay 14.8 percentage points below the measured number, outside the stated range (above it).
By their numbers in this assay, from the lowest: compounds 2 and 1 (each within the scatter of the next); then compound 3.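

In this assay, this position, on an aromatic carbon para to a large group, now gives steps beyond the scatter: the change to tert-butyl yields a number 20.7 percentage points higher from compound 2 to compound 3 (beyond the scatter), and the comparison with ethyl yields a number 11.2 percentage points higher from compound 1 to compound 3 (beyond the scatter), both modest. For the compounds shown here, the earlier pair of fluoro and ethyl could not be told apart, so the result shows for the first time that the group at this position can shift the growth inhibition, with compound 3 standing clear of both other compounds. No measurement at hand accounts for these steps. What the three compounds leave open is how an amine, a carboxylic acid or a longer chain at this position would compare with tert-butyl. They also leave open whether the steps hold at concentrations other than the single one tested.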